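The source may report more compounds than this note shows. Statements on the series, on what has been measured and on what is new or still open speak of the compounds shown alone.

Of the compounds shown here, three built on the same core have been measured in a functional assay on MCF7 cells (Homo sapiens) for cytotoxicity, read by MTT assay, with a stated time of 24 h, tested at 6.4 ug/mL; on this read-out lower numbers stand for a weaker effect and higher numbers for a stronger effect at the one concentration tested. Compound 1 `Cn1c(-c2ccc(NC(=O)CCl)cc2)nc(-c2ccccc2)c1-c1ccccc1` gives 14.2% in this assay. Compound 2 `Cn1c(-c2ccc(NC(=O)CSc3nc4cc(Cl)ccc4o3)cc2)nc(-c2ccccc2)c1-c1ccccc1` gives 27.7%, and compound 3 `Cn1cnnc1SCC(=O)Nc1ccc(-c2nc(-c3ccccc3)c(-c3ccccc3)n2C)cc1` gives 59.2%. Among these three, compound 3 stands highest: a number 45 percentage points higher from compound 1 to compound 3 (beyond the scatter) and a number 31.5 percentage points higher from compound 2 to compound 3 (beyond the scatter), both beyond the scatter. The group on the sulfur therefore matters strongly here, and a second, smaller step, a number 13.5 percentage points higher from compound 1 to compound 2 (beyond the scatter), shows that adding a ring on that sulfur already helps on its own.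

Compound 4 `Cn1c(-c2ccc(NC(=O)CSC3=NCCS3)cc2)nc(-c2ccccc2)c1-c1ccccc1` keeps everything of compound 3 except the ring attached to the sulfur, where (a group of 5 heavy atoms (3 carbon, 1 nitrogen, 1 sulfur; one five-membered non-aromatic ring with 2 hetero atoms) in place of a group of 6 heavy atoms (3 carbon, 3 nitrogen; one five-membered aromatic ring with 3 hetero atoms), on a sulfur). Among the measured compounds shown here, no measured step swaps one ring for another of this kind, so the closest guide is the large change seen when the ring on the sulfur was exchanged between compound 2 and compound 3. A drop from compound 3 seems more likely than a further rise, and compound 4 is expected to show a number 19.2 percentage points lower from compound 3 to compound 4 (beyond the scatter). The estimate for compound 4 in this assay is 40%, with a range from 20% to 62%.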

Compound 4, a percentage reported as activity, at one concentration (the size of the read-out at that concentration, not a potency): 18.6%
Estimate against measurement, compound 4: 21.4 percentage points above; the whole stated range lies above it.
By their numbers in this assay, from the lowest: compounds 1, 4 and 2 (each within the scatter of the next, the first and the last beyond it); then compound 3.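

In this assay, exchanging the 4-methyl-4H-1,2,4-triazol-3-yl for the non-aromatic five-membered ring on the sulfur gives a number 40.6 percentage points lower from compound 3 to compound 4 (beyond the scatter), so at this place one five-membered ring cannot simply stand in for another. Putting that same ring in place of the chlorine gives a number 4.4 percentage points higher from compound 1 to compound 4 (within the scatter), and putting it in place of the 5-chloro-1,3-benzoxazol-2-yl gives a number 9.1 percentage points lower from compound 2 to compound 4 (within the scatter), which shows that a ring on the sulfur does not by itself bring a gain. No measurement shown here accounts for these differences.

As far as these compounds go, the two five-membered rings differ at once in aromatic character, in their nitrogen count and in carrying a ring sulfur, so the feature that matters remains open. A 1-methylimidazol-2-yl ring or a 4-ethyl-4H-1,2,4-triazol-3-yl group on the sulfur would help to separate these features.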